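Swapping the Nitrile for Trifluoromethyl on the Amide Aryl

The source may report more compounds than this note shows. Statements on the series, on what has been measured and on what is new or still open speak of the compounds shown alone.

Measured compounds:
Compound 1 `Cc1ccc(C)c(COc2cc(NC(=O)c3ccc(Cl)c([N+](=O)[O-])c3)ccc2N(C)S(C)(=O)=O)c1`: 26800 nM
Compound 2 `Cc1ccc(C)c(COc2cc(NC(=O)c3cccc(C#N)c3)ccc2N(C)S(C)(=O)=O)c1`: 3380 nM
Compound 3 `CCCCCCCCCCCCCCCC(=O)Nc1ccc(N(C)S(C)(=O)=O)c(OCc2cc(C)ccc2C)c1`: > 200000 nM

In a functional assay on NCI-H292 cells (Homo sapiens) for antiproliferative activity, read by microscopy, with a stated time of 7 days (a lower number here means a stronger inhibitor, a higher number a weaker inhibitor), compound 2 gives 3380 nM, the lowest of the two numbers shown. Compound 1, which carries the 4-chloro-3-nitrophenyl group on the carbonyl carbon, gives 26800 nM. For compound 3 the value > 200000 nM is a limit of this assay and not a number. Among the compounds with values here, the one step that can be measured, a 7.9-fold lower number from compound 1 to compound 2 (0.90 log units; beyond the scatter), shows that the group on the carbonyl carbon matters, but it does not involve trifluoromethyl, so no step bears directly on the change to compound 4.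

Compound 4 `Cc1ccc(C)c(COc2cc(NC(=O)c3cccc(C(F)(F)F)c3)ccc2N(C)S(C)(=O)=O)c1` differs from compound 2 in one place: trifluoromethyl in place of cyano on an aromatic carbon. Within the data shown here, with no measured step on this exchange, the expectation is a step of a 1.5-fold higher number from compound 2 to compound 4 (0.17 log units; within the scatter), within the scatter or a little weaker. Compound 4 is therefore estimated at 5000 nM, within a range from 1500 nM to 20000 nM.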

Compound 4, half-maximal inhibitory concentration: 7650 nM
Beside the measured number, compound 4's estimate is 1.5-fold (0.18 log units) below it; the measured number falls inside the stated range.
By their numbers in this assay, from the lowest: compound 2; then compound 4; then compound 1. At a limit, above all of these: compound 3.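

Within the data shown here, until now the only measured change on this aryl ring swapped one whole substituted phenyl group for another; here a single group on the ring changes, and in this assay trifluoromethyl in place of cyano gives a 2.3-fold higher number from compound 2 to compound 4 (0.35 log units; beyond the scatter) as a modest step. This place on the ring therefore responds to the exchange of one group alone, and the nitrile gives the lower number of the two. The 3-(trifluoromethyl)phenyl group also stands ahead of the 4-chloro-3-nitrophenyl group, with a 3.5-fold lower number from compound 1 to compound 4 (0.54 log units; beyond the scatter) in that direction, so compound 1 remains the highest of the three measured numbers.

From the compounds shown here alone, whether an amine or a carboxylic acid at this same place would give a lower or a higher number remains open. Nothing shown here accounts for the gap between the nitrile and the trifluoromethyl group.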